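Aryl replacement on the chain: compound 3 to compound 4

This account rests on a few compounds, and the source may have more. Where it says the series, first, only, none or still open, it means among the compounds named here.

Measured so far in a functional assay on K562 cells (Homo sapiens) for antiproliferative activity, read by MTT assay, with a stated time of 24 h; a lower number here means a stronger inhibitor, a higher number a weaker inhibitor:
compound 1 `COc1ccc(C(=O)/C=C/c2ccc(F)cc2)c2c1C=CC(C)(C)O2` gives > 10000 nM
compound 2 `COc1ccc(C(=O)/C=C/c2ccco2)c2c1C=CC(C)(C)O2` gives > 10000 nM
compound 3 `COc1ccc(C(=O)/C=C/c2cccs2)c2c1C=CC(C)(C)O2` gives > 10000 nM

The value of compound 1 in this assay is a limit of the assay and not a number. The value of compound 2 is likewise a limit. The value of compound 3 is also a limit. Compound 3 therefore stands nowhere apart from the other two: all three sit together at the same limit, and none can be called stronger or weaker than another.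

The steps a step that the two limits leave unreadable from compound 1 to compound 2, a step that the two limits leave unreadable from compound 1 to compound 3 and a step that the two limits leave unreadable from compound 2 to compound 3 cannot be sized because of the limit of > 10000 nM in this assay, at which 3 of the 3 values shown sit. Three different aryl groups on the chain, one six-membered and two five-membered, have so far given no readable number.

Compound 4 `COc1ccccc1/C=C/C(=O)c1ccc(OC)c2c1OC(C)(C)C=C2` has not yet been measured. It differs from compound 3 as follows: 2-methoxyphenyl in place of thiophen-2-yl on a double-bonded chain carbon bound to a double-bonded chain carbon. Among the measured compounds shown here, no measured step bears on this change in a readable way, so no step beyond the scatter can be expected in either direction; the most likely outcome is a further limit.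

The estimate for compound 4 in this assay is 20000 nM, in the range 3000 nM to 100000 nM. The expected step is a step that the limit leaves unreadable from compound 3 to compound 4.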

Compound 4, half-maximal inhibitory concentration: > 10000 nM
Compound 4: only a limit was reported; the forecaster's own chance of this, stated with the estimate: 75%; the middle value is on the limit's open side.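

Compound 4 gives > 10000 nM, which is a limit of the assay and not a number. No step among compound 1, compound 2, compound 3 and compound 4 can be read, because all of them sit at the same limit: the limit of > 10000 nM in this assay, at which 4 of the 4 values shown sit.

The compounds shown leave open whether any aryl group at this place on the chain gives a readable number in this assay.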